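Amide aryl substituent exchange and cell toxicity

This account rests on a few compounds, and the source may have more. Where it says the series, first, only, none or still open, it means among the compounds named here.

Compound 1 `O=C(CSc1snnc1-c1ccc(Br)cc1Br)Nc1ccccc1[N+](=O)[O-]` has been tested in an ADME assay on MT4 cells (Homo sapiens) for cytotoxicity, read by MTT assay, with a stated time of 5 days; on this read-out lower numbers stand for higher toxicity in this test and higher numbers for lower toxicity in this test. In this assay compound 1 reaches only a limit, > 235000 nM, so no number is known for it; it stands at the limit of > 235000 nM in this assay, at which 1 of the 2 values shown sits. Within the data shown here, the one measured neighbour, compound 2 `O=C(CSc1snnc1-c1ccc(Br)cc1Br)Nc1cccnc1Cl`, carries 2-chloropyridin-3-yl in place of 2-nitrophenyl on the amide-type nitrogen. In this assay compound 2 likewise gives only a limit, > 240000 nM, at the limit of > 240000 nM in this assay, at which 1 of the 2 values shown sits. The step that the two limits leave unreadable from compound 1 to compound 2 therefore cannot be read in size or direction. Compound 3 `O=C(CSc1snnc1-c1ccc(Br)cc1Br)Nc1ccccc1Cl` differs from compound 1 by chloro in place of nitro on an aromatic carbon. Among the measured compounds shown here, no measured step covers this exact exchange; the two limits show only that both measured compounds sit at the upper end of what the test reports. The step that the limit leaves unreadable from compound 1 to compound 3 is expected to be none beyond the scatter. Compound 3 is expected to give 240000 nM in this assay, within 100000 nM to 500000 nM, most probably again returned only as a limit.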

Compound 3, half-maximal cytotoxic concentration: > 240000 nM
Compound 3: only a limit was reported; the forecaster's own chance of this, stated with the estimate: 85%; the middle value lies on the limit itself.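

Compound 3 gives only a limit in this assay, > 240000 nM. Among these compounds, compound 1 and compound 2 are also limits, so no step among the three compounds can be read. Where their actual cytotoxic concentrations lie, and whether these amide aryl exchanges alter them, stays open.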